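Two dimethoxy-substituted cores with a chlorophenyl arm

This account rests on a few compounds, and the source may have more. Where it says the series, first, only, none or still open, it means among the compounds named here.

Measured compounds:
compound 1, `COc1cccc(/C=C2\CCC/C(=C\c3ccccc3Cl)C2=O)c1OC`: 11300 nM
compound 2, `COc1cccc(/C=C2\CCC/C(=C\c3cccc(Cl)c3)C2=O)c1OC`: 12000 nM
compound 3, `COc1ccc(/C=C2\CCC/C(=C\c3ccccc3Cl)C2=O)cc1OC`: 10400 nM

Of the compounds shown here, three have been measured in a functional assay on MCF7 cells (Homo sapiens) for cytotoxicity, read by MTT assay, with a stated time of 72 h; on this read-out higher numbers stand for weaker inhibition and lower numbers for stronger inhibition. Compound 1 gives 11300 nM, compound 2 gives 12000 nM and compound 3 gives 10400 nM. All three numbers sit within the usual scatter of one another, so no order among them can be read from this assay.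

Compound 1 and compound 2 share a core and differ by one change, (3-chlorophenyl in place of 2-chlorophenyl on a double-bonded chain carbon bound to a double-bonded ring carbon). That change made a step of a 1.1-fold higher number from compound 1 to compound 2 (0.03 log units; within the scatter). Compound 3 carries a different core; how the two cores differ is not broken down here.

Compound 4, `COc1ccc(/C=C2\CCC/C(=C\c3cccc(Cl)c3)C2=O)cc1OC`, has not yet been measured in this assay. It stands to compound 3 as compound 2 stands to compound 1: the change is 3-chlorophenyl in place of 2-chlorophenyl on a double-bonded chain carbon bound to a double-bonded ring carbon, the same change at the same place. Among the measured compounds shown here, the only measured instance of this change, from compound 1 to compound 2, stayed within the scatter, so the step from compound 3 to compound 4 is expected to be of similar size, a 1.1-fold higher number from compound 3 to compound 4 (0.04 log units; within the scatter), resting on that single precedent and on the value of compound 3, 10400 nM. Compound 4 is therefore estimated at 11500 nM in this assay, with a range from 6500 nM to 20000 nM.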

Compound 4, half-maximal inhibitory concentration: 6000 nM
The estimate for compound 4 lay 1.9-fold (0.28 log units) above the measured number; the measured number lies below the stated range.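

In this assay, 3-chlorophenyl in place of 2-chlorophenyl on the second core gives a 1.7-fold lower number from compound 3 to compound 4 (0.24 log units; within the scatter), so this step, like the earlier one, cannot be told apart from repeat measurement. Set side by side, the two steps do not differ: the same change on two cores in this assay, a 1.1-fold higher number (0.03 log units; within the scatter) from compound 1 to compound 2 and a 1.7-fold lower number (0.24 log units; within the scatter) from compound 3 to compound 4, 1.8-fold (0.26 log units) apart, within the scatter of two such steps. On these two cores the change stayed inside the scatter both times and nothing separates its outcome on one core from its outcome on the other, but two pairs do not show that the change is without consequence throughout the series, nor that it would behave the same way on a further core.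

Every compound shown carries a chlorophenyl arm and a dimethoxy-substituted core, so how this assay would read for an arm bearing an amine or a carboxylic acid in place of the chlorine remains open. Also open is whether this same change stays within the scatter on a core without the two methoxy groups, and whether any of these compounds would separate from the others in a different read-out.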